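The source may hold more compounds than are shown below. What is called first, only, known or untested is meant among the compounds shown, and "the series" means these compounds.

Of the compounds shown here, two have so far been measured in a functional assay on XF498 cells (Homo sapiens) for cytotoxicity; on this read-out higher numbers stand for an effect only at larger amounts of compound and lower numbers for an effect already at smaller amounts. Compound 1 `C=CCCCCCC#CC#CC(O)CC(C)=O` carries a 2-oxopropyl group and closes with a double bond at the far end of its chain; in this assay compound 1 gives 3.87 ug/mL. Compound 2 `CCCCCCCC#CC#CCO` is the simpler alcohol, and in this assay compound 2 gives 5.59 ug/mL. Compound 2 thus stands with compound 1 inside the scatter of repeated measurements, and the two numbers cannot be ranked against each other.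

Compound 3 `CCCCCCCC#CC#CC(O)CC(C)=O` is the next compound to be measured in this assay. It differs from compound 2 in one place: 2-oxopropyl in place of hydrogen on a saturated chain carbon bound to an oxygen on a saturated carbon and a triple-bonded carbon. The same group sits in compound 1, which otherwise differs only in how its chain ends. Among the measured compounds shown here, no step between two measured compounds is available to lean on, so the expectation rests on compound 1 giving 3.87 ug/mL. The step from compound 2 to compound 3 is estimated at a 1.4-fold lower number from compound 2 to compound 3 (0.15 log units; within the scatter), that is, a small move toward a lower number or none beyond the scatter. Compound 3 is therefore expected to give about 4 ug/mL in this assay, within a range from 1.8 ug/mL to 9 ug/mL.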

Compound 3, concentration for half-maximal effect: 3.7 ug/mL
For compound 3 the middle estimate is 1.1-fold (0.03 log units) above the measured one; measured number inside the range.
By their numbers in this assay, from the lowest: compounds 3, 1 and 2 (each within the scatter of the next).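

Read as a single change for the first time in this assay, 2-oxopropyl in place of hydrogen on a saturated chain carbon bound to an oxygen on a saturated carbon and a triple-bonded carbon comes to a small step (a 1.5-fold lower number from compound 2 to compound 3 (0.18 log units; within the scatter)), so this read-out does not separate the compounds with and without the group. The far end of the chain can now be read on its own as well: ethyl in place of vinyl on a saturated chain carbon, five bonds along the chain from a triple-bonded carbon, gives an equally unresolved step (a 1.0-fold lower number from compound 1 to compound 3 (0.02 log units; within the scatter)), and the two forms of the chain end cannot be told apart here. Nothing at hand bears on what lies behind either result.

The compounds shown leave open whether any group at this carbon can move the number beyond the scatter, for instance an amine or a carboxylic acid in place of 2-oxopropyl. They also leave open whether a longer chain or a shorter one would do so, since both changes read here stay within the scatter.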